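A few compounds are considered here, and "the series" means these few. Any claim that something is new, unique, unknown or untested is made for them only; others in the source may bear on it.

Measured compounds in an ADME assay on HEK293 cells (Homo sapiens) for cytotoxicity, read by MTT assay; a higher number here means a weaker inhibitor, a lower number a stronger inhibitor:

- compound 1 `Cc1cccc(/C=C/C(=O)c2c(O)cc(C)oc2=O)c1`: 100000 nM
- compound 2 `Cc1cc(O)c(C(=O)/C=C/c2cc(Br)cs2)c(=O)o1`: 100000 nM
- compound 3 `Cc1cc(O)c(C(=O)/C=C/c2cccc(C(F)(F)F)c2)c(=O)o1`: > 100000 nM (a limit of the assay, not a number)

In this assay compound 1 gives 100000 nM and compound 2 gives 100000 nM. For compound 3 only a limit is recorded, > 100000 nM. Within the data shown here, compound 3 thus stands at the top of what this assay reports, and the one step reaching it, a number no lower from compound 1 to compound 3 (the limit leaves the size open), has a size that cannot be read, as it ends at the limit (the limit of > 100000 nM in this assay, at which 1 of the 3 values shown sits).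

Compound 4 `CCOc1cccc(/C=C/C(=O)c2c(O)cc(C)oc2=O)c1` differs from compound 3 by ethoxy in place of trifluoromethyl on an aromatic carbon. Among the measured compounds shown here, no measured step covers this exchange. For the measured compounds named here, the only step bearing on this position, a number no lower from compound 1 to compound 3 (the limit leaves the size open), shows no readable movement, and every value sits at or beyond the same ceiling. No step beyond the scatter is therefore expected in this assay; compound 4 is estimated at 100000 nM, with a range from 40000 nM to 250000 nM. The expected step from compound 3 is a number no higher from compound 3 to compound 4 (the limit leaves the size open), with a real chance that compound 4 again yields only a limit.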

Compound 4, half-maximal inhibitory concentration: 80000 nM
Estimate against measurement, compound 4: 1.3-fold (0.10 log units) above; measured number inside the range.
By their numbers in this assay, from the lowest: compounds 4, 1 and 2 (each within the scatter of the next).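

In this assay the ethoxy of compound 4 gives a readable number on this aromatic carbon, meta to a large group, and it adds a group carrying a hydrogen-bond acceptor to the methyl and trifluoromethyl seen before. Set against methyl, the exchange gives a 1.3-fold lower number from compound 1 to compound 4 (0.10 log units; within the scatter) and so does not separate the two groups. Set against trifluoromethyl, it gives an at least 1.2-fold lower number from compound 3 to compound 4 (0.09 log units; that floor lies within the scatter) as its reading, which is only a floor, as the value for compound 3 is a limit of the assay and not a number: the limit of > 100000 nM in this assay, at which 1 of the 4 values shown sits.

As far as these compounds go, whether any group at this position can bring the number clearly down remains open, as methyl and ethoxy lie within the scatter of each other. An amine, a carboxylic acid or a longer alkoxy chain on this carbon would test that.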